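One methoxy fewer on the carbonyl-side ring

A few compounds are considered here, and "the series" means these few. Any claim that something is new, unique, unknown or untested is made for them only; others in the source may bear on it.

In a functional assay on KM12 cells (Homo sapiens) for inhibition, read by sulforhodamine B assay, with a stated time of 48 h (a higher number here means that more compound is tolerated, a lower number that less compound is tolerated), compound 1 `COc1cc(-c2cc(/C=C/C(=O)c3ccc(N)cc3)[nH]n2)cc(OC)c1OC` gives 7270 nM. Compound 2 `COc1cc(-c2cc(/C=C/C(=O)c3ccc(Cl)c(Cl)c3)[nH]n2)cc(OC)c1OC` reaches only a limit of this assay, > 100000 nM, namely (the limit of > 100000 nM in this assay, at which 1 of the 3 values shown sits). Compound 3 `COc1ccc(C(=O)/C=C/c2cc(-c3cc(OC)c(OC)c(OC)c3)n[nH]2)cc1OC` gives 5430 nM, the lowest of the two numbers shown; the steps reaching it are a 1.3-fold lower number from compound 1 to compound 3 (0.13 log units; within the scatter) and an at least 18-fold lower number from compound 2 to compound 3 (1.26 log units; beyond the scatter). Compound 4 `COc1ccc(C(=O)/C=C/c2cc(-c3cc(OC)c(OC)c(OC)c3)n[nH]2)cc1` differs from compound 3 by hydrogen in place of methoxy on an aromatic carbon. Among the compounds with values here, no measured step removes a single methoxy: the exchange of whole aryl groups between compound 1 and compound 3 stayed within the scatter, and only the move to 3,4-dichlorophenyl was large. The loss of one methoxy is therefore expected to shift this assay little. Compound 4 is estimated at 7000 nM, between 2500 nM and 20000 nM. That estimate is expected to mean a 1.3-fold higher number from compound 3 to compound 4 (0.11 log units; within the scatter).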

Compound 4, concentration lethal to 50% of the cells: 6020 nM
Estimate against measurement, compound 4: 1.2-fold (0.07 log units) above; the measured number falls inside the stated range.
By their numbers in this assay, from the lowest: compounds 3, 4 and 1 (each within the scatter of the next). At a limit, above all of these: compound 2.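

In this assay, hydrogen in place of methoxy gives a 1.1-fold higher number from compound 3 to compound 4 (0.04 log units; within the scatter), so at this position on the ring these two compounds cannot be told apart. Methoxy in place of amino likewise gives a 1.2-fold lower number from compound 1 to compound 4 (0.08 log units; within the scatter), while 4-methoxyphenyl in place of 3,4-dichlorophenyl gives an at least 16-fold lower number from compound 2 to compound 4 (1.22 log units; beyond the scatter), which keeps the dichloro compound as the only large departure. Compound 2 stands at a limit, not a number: the limit of > 100000 nM in this assay, at which 1 of the 4 values shown sits.

The compounds shown leave open what a single chlorine, a hydroxyl or a fluorine would do at this position. They also leave open what happens when the remaining methoxy is replaced by hydrogen, which would give an unsubstituted phenyl.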